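Swapping cyano for 2-methoxyphenyl on compound 2

The compounds below may be only part of what the source reports. "The series", "measured", "known", "first", "only" and "open" are said of these compounds alone.

Compound 1 `CC1CCN(C2CCN(S(=O)(=O)c3cccnc3Cl)CC2)CC1` gives > 10000 nM
Compound 2 `CC1CCN(C2CCN(S(=O)(=O)c3ccc(C#N)cc3)CC2)CC1` gives > 5000 nM
Compound 3 `CC1CCN(C2CCN(S(=O)(=O)c3ccccc3Br)CC2)CC1` gives > 5000 nM

All three entries come from an ADME assay on HCT-116 cells (Homo sapiens) for cytotoxicity, read by CellTiter-Glo, with a stated time of 72 h (a higher number here means a weaker inhibitor, a lower number a stronger inhibitor), and each is a limit of the assay, not a number. The reading for compound 2 is > 5000 nM and that is a limit. Two limits hold all the values: the limit of > 10000 nM in this assay, at which 1 of the 3 values shown sits, and the limit of > 5000 nM in this assay, at which 2 of the 3 values shown sit, together.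

Within the data shown here, compound 4 `COc1ccccc1-c1ccc(S(=O)(=O)N2CCC(N3CCC(C)CC3)CC2)cc1` has no measurement yet. It carries 2-methoxyphenyl in place of cyano on an aromatic carbon, para to a large group. The counted change reads 2-methoxyphenyl in place of cyano on an aromatic carbon in full.

The nearest evidence comes from swaps of the whole group on the sulfonyl sulfur, namely a step that the two limits leave unreadable from compound 1 to compound 2 and a step that the two limits leave unreadable from compound 2 to compound 3 and neither has a size that can be read. No size can be carried over to the new change, so no step beyond the usual scatter is expected, in either direction. The expected move is a number no higher from compound 2 to compound 4 (the limit leaves the size open) as an estimate. For compound 4 the estimate is 5000 nM with an expected range from 1500 nM to 15000 nM and the reading may well be a limit again.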

Compound 4, half-maximal inhibitory concentration: > 5000 nM
Compound 4 gave a limit, no number; the forecaster's own chance of this, stated with the estimate: 60%; the middle value lies on the limit itself.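

In this assay compound 4 gives > 5000 nM, which is a limit and not a number. Compound 2 also gives a limit, so no step can be read from compound 2 to compound 4, because both readings sit at the same limit: the limit of > 5000 nM in this assay, at which 3 of the 4 values shown sit.

The compounds shown leave open whether 2-methoxyphenyl in place of cyano changes the true value at all, and in which direction.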